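This account rests on a few compounds, and the source may have more. Where it says the series, first, only, none or still open, it means among the compounds named here.

Compound 2 `CCC1C(=O)N(CCCCCCCOc2ccc(Cl)cc2)/C(=N\C#N)N1c1ccncc1` gives 3530 nM in a functional assay on DLD-1 cells (Homo sapiens) for cytotoxicity; on this read-out lower numbers stand for stronger inhibition and higher numbers for weaker inhibition; compound 1 `CCC1C(=O)N(CCCCCCOc2ccc(Cl)cc2)/C(=N\C#N)N1c1ccncc1` gives 3560 nM, and the two sit within the scatter of each other, the step of a 1.0-fold lower number from compound 1 to compound 2 (0.00 log units; within the scatter) being flat. Compound 3 `N#C/N=C1\N(CCCCCCCOc2ccc(Cl)cc2)C(=O)C(c2ccccc2)N1c1ccncc1` differs from compound 2 by phenyl in place of ethyl on a saturated ring carbon. Within the data shown here, no measured step touches that ring carbon; the only known step concerns the chain and lay within the scatter, so the series gives no lead on direction or size. The step expected in this assay is a 1.0-fold lower number from compound 2 to compound 3 (0.00 log units; within the scatter), with wide uncertainty. Compound 3 is estimated at 3500 nM, with a range from 1000 nM to 12000 nM.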

Compound 3, half-maximal inhibitory concentration: 290 nM
The estimate for compound 3 lay 12-fold (1.08 log units) above the measured number; measured number below the stated range.
By their numbers in this assay, from the lowest: compound 3; then compounds 2 and 1 (each within the scatter of the next).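

In this assay, the saturated ring carbon responds strongly to its substituent: phenyl in place of ethyl gives a 12-fold lower number from compound 2 to compound 3 (1.09 log units; beyond the scatter). This is the only step shown that lies beyond the scatter, so this ring carbon matters more to the read-out than the chain change between compound 1 and compound 2. No available data explain the gain. Still open, going by these compounds, is whether the aromatic ring itself is needed, which cyclohexyl or benzyl at this carbon would test. Also open, on these data alone, is whether the chain remains as flat with phenyl present.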